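A few compounds are considered here, and "the series" means these few. Any claim that something is new, unique, unknown or untested is made for them only; others in the source may bear on it.

In an assay for inhibition of Tryptophan 2,3-dioxygenase (Homo sapiens), with stated times of 10 min and 60 min, tested at 10 uM (on this read-out higher numbers stand for a stronger effect at the one concentration tested and lower numbers for a weaker effect), compound 1 `Oc1ccc(CNc2cc(C(F)(F)F)cc3[nH]ncc23)cc1` gives 75% and compound 2 `O=[N+]([O-])c1cc(Cl)ccc1CNc1cc(C(F)(F)F)cc2[nH]ncc12` gives 90%, while compound 3 `FC(F)(F)c1cc(NCC2CNC2)c2cn[nH]c2c1` gives 5%, the lowest of the three numbers. Going by the values given here, the one measured step that reaches compound 3 is a number 70 percentage points lower from compound 1 to compound 3 (beyond the scatter), where the saturated ring took the place of an aromatic group. Compound 4 `FC(F)(F)c1cc(NC[C@H]2CCCCN2)c2cn[nH]c2c1` differs from compound 3 by piperidin-2-yl in place of azetidin-3-yl on a saturated chain carbon bound to a nitrogen on an aromatic ring. Among the compounds with values here, no measured step trades one saturated nitrogen ring for another, so this change has no direct precedent here; what is known is that compound 3 sits far below compounds 1 and 2. Compound 4 is therefore expected to stay near compound 3, with a step of a number 7 percentage points higher from compound 3 to compound 4 (within the scatter) in this assay, not beyond the scatter. The estimated value of compound 4 is 12%, in the range 0% to 35%.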

Compound 4, a percentage reported as inhibition, at one concentration (the size of the read-out at that concentration, not a potency): 69%
Compound 4: middle estimate off by 57 percentage points, on the low side, and the stated range ends below it.
By their numbers in this assay, from the lowest: compound 3; then compounds 4 and 1 (each within the scatter of the next); then compound 2.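

In this assay, a saturated nitrogen ring at this place does not in itself lose the effect: there is a number 64 percentage points higher from compound 3 to compound 4 (beyond the scatter) and also a number 6 percentage points lower from compound 1 to compound 4 (within the scatter). The earlier step from the aromatic group to azetidin-3-yl therefore reflects that particular ring, not saturated rings in general, at least across these compounds. Nothing available here accounts for the gap between the two rings. The compounds shown leave open whether ring size or point of attachment carries the step, which pyrrolidin-2-yl or piperidin-3-yl would help separate. As far as these compounds go, the opposite stereocentre of piperidin-2-yl also remains open.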